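Amide substituent size and sirtuin-6 inhibition in one series

The source may report more compounds than this note shows. Statements on the series, on what has been measured and on what is new or still open speak of the compounds shown alone.

Compound 2 `CCCCCCCCCCCCCNC(=O)CCCSC[C@H](NC(=O)OCc1ccccc1)C(=O)Nc1ccccc1` gives 31% in an assay for inhibition of NAD-dependent protein deacylase sirtuin-6 (Homo sapiens), read by HPLC, with stated times of 15 min and 1 h, tested at 333 uM (a higher number here means more inhibition at the concentration tested (going by the name of the read-out), a lower number less inhibition), the higher of the two numbers reported so far; compound 3 `O=C(CCCSC[C@H](NC(=O)OCc1ccccc1)C(=O)Nc1ccccc1)NCc1ccccc1` gives 30%, and the step of a number 1 percentage points lower from compound 2 to compound 3 (within the scatter) lies within the scatter. Compound 1 `CCCCCCNC(=O)CCCSC[C@H](NC(=O)OCc1ccccc1)C(=O)Nc1ccccc1` is reported as "not active" (no number reported), without a number. Compound 4 `CNC(=O)CCCSC[C@H](NC(=O)OCc1ccccc1)C(=O)Nc1ccccc1` is not yet measured and differs from compound 2 by hydrogen in place of dodecyl on a saturated chain carbon bound to an amide-type nitrogen. Among the measured compounds shown here, no measured step bears directly on this change: the one measured step, a number 1 percentage points lower from compound 2 to compound 3 (within the scatter), exchanges one large group for another. Compound 1 and compound 2 together show that the shorter chain came back without a number. The expected step is a number 23 percentage points lower from compound 2 to compound 4 (beyond the scatter), a drop beyond the scatter, with a fair chance that no number is reported. Compound 4 is estimated at 8%, between 0% and 20%.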

Compound 4, a percentage reported as inhibition, at one concentration (the size of the read-out at that concentration, not a potency): "not active" (no number reported)
Compound 4 has no reported number here, so the estimate cannot be set against anything.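

Among the compounds shown here, compound 4 is reported in this assay as "not active" (no number reported), so no step from compound 2 to compound 4 can be read. The compounds shown leave open how much inhibition, if any, compound 1 and compound 4 retain. No measurement here bears on this result.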